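The source may report more compounds than this note shows. Statements on the series, on what has been measured and on what is new or still open speak of the compounds shown alone.

Measured compounds:
compound 1, `CS(=O)(=O)NC(=O)CCC/C=C\C[C@@H]1[C@@H](/C=C/[C@@H](O)COc2ccccc2)[C@H](O)C[C@@H]1O`, in a functional assay on CHO cells for agonist activity at prostaglandin E2 receptor EP3 subtype (Homo sapiens), read by fluorescence and calcium flux (on this read-out lower numbers stand for an effect already at smaller amounts and higher numbers for an effect only at larger amounts of compound), compound 1 gives 0.34 nM
compound 2, `O=C(O)CCC[C@@H]1CC[C@@H]2[C@@H](/C=C/[C@@H](O)COc3ccccc3)[C@H](O)C[C@@H]2O1`, in this assay compound 2 gives 4.1 nM

Of these two numbers, compound 2 has the higher one, so in this assay it takes effect only at a larger amount than compound 1; the gap between them lies beyond the usual scatter. Compound 3, `O=C(O)CCC[C@H]1CC[C@@H]2[C@@H](/C=C/[C@@H](O)COc3ccccc3)[C@H](O)C[C@@H]2O1`, is the next step from compound 2. The change is the two compounds have the same atoms and bonds and differ only in configuration as drawn: 1 of 7 stereo elements differ; a stereocentre at a saturated ring carbon is drawn R in compound 2 and S in compound 3: nothing is added or taken away, only the drawn configuration at one saturated ring carbon is flipped. For the measured compounds named here, no measured pair here shows what such a flip does, so the size of the step is open. A change of configuration at a ring carbon in compounds of this kind is expected to move the number, and the more likely direction is upward, toward an effect only at larger amounts. Compound 3 is therefore expected to give about 30 nM in this assay, within a wide range from 4 nM to 300 nM, which means an expected step of a 7.3-fold higher number from compound 2 to compound 3 (0.86 log units; beyond the scatter).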

Compound 3, half-maximal effective concentration: 3.6 nM
Beside the measured number, compound 3's estimate is 8.3-fold (0.92 log units) above it; measured number below the stated range.
By their numbers in this assay, from the lowest: compound 1; then compounds 3 and 2 (each within the scatter of the next).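

In this assay the result is a 1.1-fold lower number from compound 2 to compound 3 (0.06 log units; within the scatter), so drawing this saturated ring carbon S instead of R gives no difference that can be told apart from the scatter of repeated measurements. The earlier compounds shown here could not show this, since compound 1 and compound 2 differ in more than one place and no step between them can be read for this position. The pair tests this one stereocentre alone, because nothing else separates the two compounds: the fact that compounds 2 and 3 differ only in the configuration as drawn

Still open, on these data alone, is whether the same flip would leave the number just as unmoved with a tetrazole in place of the carboxylic acid, or with a longer chain carrying that acid. Also open, as far as these compounds go, is what a flip at any of the other stereo elements would do.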